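Compound 4: swapping 4-chlorophenyl for 2-phenylethenyl

The source may hold more compounds than are shown below. What is called first, only, known or untested is meant among the compounds shown, and "the series" means these compounds.

Measured in an ADME assay on HL-60 cells (Homo sapiens) for cytotoxicity, read by MTT assay, with a stated time of 24 h; a higher number here means a weaker inhibitor, a lower number a stronger inhibitor:
- compound 1 `CN1CCC=C(c2ccc(CN(C)C/C=C/c3ccccc3)cc2)C1`: > 50000 nM (a limit)
- compound 2 `CN(C/C=C/c1ccccc1)Cc1ccc(C2CCCN(C)C2)cc1`: > 50000 nM (a limit)
- compound 3 `CN(Cc1ccc(Cl)cc1)Cc1ccc(-c2cccnc2)cc1`: 21000 nM

Not yet measured: compound 4 `CN(C/C=C/c1ccccc1)Cc1ccc(-c2cccnc2)cc1`

Among the measured compounds shown here, compound 3, at 21000 nM, holds the only true number in this assay. The other two results stand at the limit of > 50000 nM in this assay, at which 2 of the 3 values shown sit.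

Compound 4 keeps the core of compound 3 and changes one group: 2-phenylethenyl in place of 4-chlorophenyl on a saturated chain carbon bound to an amine nitrogen. In short, 2-phenylethenyl replaces 4-chlorophenyl.

For the measured compounds named here, the only measured step is a step that the two limits leave unreadable from compound 1 to compound 2, so it offers no size to carry over. The two limits still give a hint, though compound 1 and compound 2 have a different core from compound 3. Compound 1 carries 2-phenylethenyl and reads > 50000 nM, a limit. Compound 2 also carries it and reads > 50000 nM, again a limit.

The expected change is a modest one toward weaker inhibition, a 1.4-fold higher number from compound 3 to compound 4 (0.15 log units; within the scatter). For compound 4 the estimate is 30000 nM, with an expected range of 12000 nM to 50000 nM.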

Compound 4, half-maximal inhibitory concentration: 44000 nM
For compound 4 the middle estimate is 1.5-fold (0.17 log units) below the measured one; the range from low to high includes it.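

In this assay, the group on a saturated chain carbon bound to an amine nitrogen now has a readable effect: 2-phenylethenyl in place of 4-chlorophenyl gives a 2.1-fold higher number from compound 3 to compound 4 (0.32 log units; beyond the scatter). Pyridin-3-yl in place of 1-methylpiperidin-3-yl gives an at least 1.1-fold lower number from compound 2 to compound 4 (0.05 log units; that floor lies within the scatter), and the matching ring change from the core of compound 1 gives an at least 1.1-fold lower number from compound 1 to compound 4 (0.05 log units; that floor lies within the scatter), so these two steps show no change beyond the scatter. These two steps are only floors, because compound 1 and compound 2 each stand at a limit rather than a number: the limit of > 50000 nM in this assay, at which 2 of the 4 values shown sit.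

The step from compound 3 to compound 4 changes the ring substituent and the chain together, so it cannot show which of the two matters. A plain phenyl or a saturated 2-phenylethyl group at this place would be needed to separate them.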